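The compounds below may be only part of what the source reports. "The series", "measured", "known", "first", "only" and "open" are said of these compounds alone.

Compound 1 `CC(C)(C)[C@@H](O)C(=O)N1OCC[C@H]1C(=O)NCc1cc(Cl)ccc1-n1cnnn1` and compound 3 `CC(C)(C)C[C@@H](O)C(=O)N1OCC[C@H]1C(=O)NCc1cc(Cl)ccc1-n1cnnn1` share one core and differ in a single place, (neopentyl in place of tert-butyl on a saturated chain carbon bound to a carbonyl carbon and an oxygen on a saturated carbon). In an ADME assay on liver for metabolic stability, with Liver microsome (Homo sapiens) as the target, read by LC-MS, using microsomes (on this read-out lower numbers stand for slow clearance and higher numbers for fast clearance), compound 1 gives a reading of < 12 mL.min-1.g-1, which is a limit of the assay rather than a number. In this assay compound 3 likewise gives < 12 mL.min-1.g-1, again a limit and not a number. The step between them, a step that the two limits leave unreadable from compound 1 to compound 3, cannot be read because of the limit of < 12 mL.min-1.g-1 in this assay, at which 2 of the 3 values shown sit. Compound 2 `CC(C)(C)[C@@H](O)C(=O)N1[C@H](C(=O)NCc2cc(Cl)ccc2-n2cnnn2)C[C@@H]2C[C@@H]21` is built on a different core, and the difference between the two cores is not broken down here. In this assay compound 2 gives 75 mL.min-1.g-1, the only reading among these three that is a number. Compound 4 `CC(C)(C)C[C@@H](O)C(=O)N1[C@H](C(=O)NCc2cc(Cl)ccc2-n2cnnn2)C[C@@H]2C[C@@H]21` carries the same change that separates compound 1 from compound 3, (neopentyl in place of tert-butyl on a saturated chain carbon bound to a carbonyl carbon and an oxygen on a saturated carbon). What this change does to clearance is not known from the pair already measured, as both of those readings are limits. Starting from compound 2, the expected step to compound 4 is small, no change at the digits printed from compound 2 to compound 4 (within the scatter). The estimate for compound 4 in this assay is 75 mL.min-1.g-1, expected to fall between 35 mL.min-1.g-1 and 160 mL.min-1.g-1.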

Compound 4, intrinsic clearance in microsomes: 40 mL.min-1.g-1
For compound 4 the middle estimate is 1.9-fold (0.27 log units) above the measured one, within the range that was stated.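

In this assay, neopentyl in place of tert-butyl on the core of compound 2 gives a 1.9-fold lower number from compound 2 to compound 4 (0.27 log units; within the scatter), so on this core the change cannot be told apart from the ordinary spread of repeated measurements. On the core of compound 1 the same change cannot be read, because the readings on both sides of it are limits of the assay and not numbers: the limit of < 12 mL.min-1.g-1 in this assay, at which 2 of the 4 values shown sit. Among these compounds, the pair on the core of compound 2 therefore shows only that the change stays within the scatter on that one core, and it does not show that the change has the same size, or any size, on the core of compound 1.

Going by these compounds, it remains open whether a longer chain, a carboxylic acid or an amine in the same place would give a step beyond the scatter on the core of compound 2. On these data alone, it also remains open what any such group would do on the core of compound 1, where a step can be read only if at least one of its two readings is a number.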